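The source may hold more compounds than are shown below. What is called first, only, known or untested is meant among the compounds shown, and "the series" means these compounds.

Measured compounds:
compound 1 `ClCc1ccccc1Cn1cnc2c(Cl)nc(Cl)nc21`, 1820 nM in a functional assay on SK-OV-3 cells (Homo sapiens) for cytotoxicity, read by sulforhodamine B assay, with a stated time of 48 h; on this read-out higher numbers stand for weaker inhibition of growth and lower numbers for stronger inhibition of growth
compound 3 `Nc1nc(Cl)c2ncn(Cc3ccccc3CCl)c2n1`, 15500 nM in this assay
compound 2 `ClCc1cccc(Cn2cnc3c(Cl)nc(Cl)nc32)c1`, "not determined" (no result reported) in this assay

Within the data shown here, the one measured step is amino in place of chloro on an aromatic carbon, which gave an 8.5-fold higher number from compound 1 to compound 3 (0.93 log units; beyond the scatter). Compound 4 `Nc1nc(Cl)c2ncn(Cc3cccc(CCl)c3)c2n1` carries the same change on the core of compound 2: amino in place of chloro on an aromatic carbon, with the place described in identical words. How the core of compound 2 differs from that of compound 1 is not broken down here. Among the measured compounds shown here, since compound 2 has no value in this assay, no step from compound 2 to compound 4 can be sized; the expectation rests instead on compound 3, which gives 15500 nM with the same amino group already in place. Compound 4 is expected to show roughly 15000 nM in this assay, plausibly between 4000 nM and 55000 nM.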

Compound 4, concentration for 50% growth inhibition: 24000 nM
Estimate against measurement, compound 4: 1.6-fold (0.20 log units) below; the range from low to high includes it.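

In this assay, among these compounds, compound 2 gives no number, so no step from it to compound 4 can be read. No evidence here accounts for the result. Left open is whether amino in place of chloro acts on the core of compound 2 as it does on the core of compound 1.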